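A few compounds are considered here, and "the series" means these few. Any claim that something is new, unique, unknown or untested is made for them only; others in the source may bear on it.

Measured in a physicochemical assay for lipophilicity; on this read-out lower numbers stand for lower lipophilicity and higher numbers for higher lipophilicity:
compound 1, `CNC(=O)c1cc(C(=O)N[C@H]2CC[C@H](O)CC2)c([C@@H](C)c2cccc(C)c2)o1`: 3.3
compound 2, `CNC(=O)c1cc(C(=O)NCCO)n([C@@H](C)c2ccccc2)n1`: 2.4

Compound 2 stands lowest of the two values; compound 1 lies higher by a margin beyond the scatter. Compound 3, `CNC(=O)c1cc(C(=O)N[C@H]2CC[C@H](OC)CC2)n([C@@H](C)c2ccccc2)n1`, is not yet measured. Its difference from compound 2 is 4-methoxycyclohexyl in place of 2-hydroxyethyl on an amide-type nitrogen, a six-membered non-aromatic ring entering where a group with no ring leaves, and the hydrogen-bond donor going with it. For the measured compounds named here, no step between measured compounds exists to calibrate this, so the expectation rests on the change alone: a rise in this assay well beyond the scatter is expected, estimated as a number 1.20 log units higher from compound 2 to compound 3 (beyond the scatter). Compound 3 is expected to give 3.6, within 3 to 4.2.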

Compound 3, distribution coefficient: 4.2
Compound 3: the middle estimate sits 0.60 log units below what was measured; the measured number falls inside the stated range.
By their numbers in this assay, from the lowest: compound 2; then compound 1; then compound 3.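

In this assay, for the compounds shown here, this amide-type nitrogen proves highly sensitive to its substituent: 4-methoxycyclohexyl in place of 2-hydroxyethyl gives a number 1.80 log units higher from compound 2 to compound 3 (beyond the scatter) in a single replacement, the first calibrated step. Compound 1 differs from compound 3 in more than one place, so it adds nothing to this reading. No available evidence accounts for the size of the step.

The step combines the entering ring, the methoxy group and the departing hydrogen-bond donor, so their separate contributions remain unresolved. As far as these compounds go, how a cyclohexyl ring carrying an amine or a carboxylic acid in place of the methoxy group would read also stays open.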